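Ethyl ester series: cyclopentylamino to 4-fluorobenzylamino

This account rests on a few compounds, and the source may have more. Where it says the series, first, only, none or still open, it means among the compounds named here.

Measured so far:
compound 1 `CNC(=O)c1cnc(NC(=O)NC2CCCCC2)n2nc(-c3ccco3)nc12`, 18700 nM
compound 2 `CCOC(=O)c1cnc(NC2CCCC2)n2nc(-c3ccco3)nc12`, 35 nM

Within the data shown here, in an assay on CHO cells for displacement of a labelled ligand from adenosine receptor A3 (Homo sapiens) (on this read-out lower numbers stand for stronger inhibition and higher numbers for weaker inhibition), compound 2 gives 35 nM, the lowest of the two numbers, while compound 1 gives 18700 nM; the two values lie far apart, beyond the scatter, and no single step connects them. Compound 3 `CCOC(=O)c1cnc(NCc2ccc(F)cc2)n2nc(-c3ccco3)nc12` is not yet measured. It differs from compound 2 by 4-fluorobenzyl in place of cyclopentyl on a nitrogen on an aromatic ring. Among the measured compounds shown here, with no step of this kind known, a modest change in this assay is expected, possibly within the scatter in either direction, for compound 3 as a 1.4-fold lower number from compound 2 to compound 3 (0.15 log units; within the scatter). Compound 3 is estimated at 25 nM, with a range of 5 nM to 150 nM.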

Compound 3, inhibition constant: 46.3 nM
Compound 3: the middle estimate sits 1.9-fold (0.27 log units) below what was measured; the range from low to high includes it.
By their numbers in this assay, from the lowest: compounds 2 and 3 (each within the scatter of the next); then compound 1.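

Replacing the ring on the nitrogen gives a 1.3-fold higher number from compound 2 to compound 3 (0.12 log units; within the scatter) in this assay and so no separation between the two compounds. This position therefore accepts 4-fluorobenzyl, with its six-membered aromatic ring, as well as cyclopentyl, with its five-membered non-aromatic ring, at least in the ethyl ester series. Nothing at hand gives a reason for this equivalence. 

From the compounds shown here alone, whether the fluorine matters remains open, and plain benzyl on the same nitrogen would address that. A longer chain such as phenethyl would show whether the tolerance extends further from the nitrogen.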